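Isopropyl on the anilino ring of compound 3

This account rests on a few compounds, and the source may have more. Where it says the series, first, only, none or still open, it means among the compounds named here.

Measured so far:
Compound 1 `Cc1ccccc1Nc1nc(NC2CCCCC2)ncc1Cl` gives in a functional assay on MCF7 cells (Homo sapiens) for inhibition, read by CCK-8 assay, with a stated time of 48 h (a higher number here means a weaker inhibitor of growth, a lower number a stronger inhibitor of growth), only a limit, > 100000 nM.
Compound 2 `Cc1ccc(Nc2ncc(Cl)c(Nc3ccccc3C)n2)cc1` gives in this assay only a limit, > 100000 nM.
Compound 3 `CN1CCN(c2ccc(Nc3ncc(Cl)c(Nc4ccccc4)n3)nc2)CC1` gives in this assay 51800 nM.

Going by the values given here, compound 3 thus holds the only number in this set; the two other values sit at a limit, as the limit of > 100000 nM in this assay, at which 2 of the 3 values shown sit, records. Among the compounds with values here, the single step between measured compounds, a step that the two limits leave unreadable from compound 1 to compound 2, is not readable, so no measured step says how a change on the anilino ring moves growth inhibition.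

Compound 4 `CC(C)c1ccccc1Nc1nc(Nc2ccc(N3CCN(C)CC3)cn2)ncc1Cl` differs from compound 3 by isopropyl in place of hydrogen on an aromatic carbon. Within the data shown here, no measured step bears on this change, and nothing in the set speaks for a move in either direction. The working expectation is therefore a step no larger than the scatter, a 1.2-fold lower number from compound 3 to compound 4 (0.06 log units; within the scatter), from compound 3 to compound 4. Compound 4 is expected to give about 45000 nM in this assay, estimated between 15000 nM and 100000 nM, with a real chance that only a limit is reported.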

Compound 4, concentration for 50% growth inhibition: 4360 nM
Compound 4: the middle estimate sits 10-fold (1.01 log units) above what was measured; measured number outside the range, below it.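

The position ortho to a large group on the anilino ring of compound 3 responds clearly in this assay, where isopropyl in place of hydrogen gives a 12-fold lower number from compound 3 to compound 4 (1.07 log units; beyond the scatter). Going by these compounds alone, this is the first readable step, and the one step among the earlier compounds cannot be read: the limit of > 100000 nM in this assay, at which 2 of the 4 values shown sit. The entering group holds only carbon, with no ring, no hydrogen-bond donor or acceptor and no net charge, so a change of this plain kind at this place is enough for a step beyond the scatter.

On these data alone, whether the step needs isopropyl itself stays open, as methyl, ethyl, tert-butyl or cyclopropyl at the same place would show. Also open, as far as these compounds go, is how a methoxy group, an amine or a carboxylic acid there would compare.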